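The source may report more compounds than this note shows. Statements on the series, on what has been measured and on what is new or still open speak of the compounds shown alone.

Of the compounds shown here, three that share a core have been tested in a functional assay on the whole organism (strain Sprague-Dawley) with Rattus norvegicus as the target, with a stated time of 4 days, at a dose of 10 mg/kg by the oral route; on this read-out lower numbers stand for less inhibition and higher numbers for more inhibition at the one dose given (going by the name of the read-out). Compound 1, `COc1cc(-n2cnn3cc(-c4ccc(Cl)cc4)cc3c2=O)ccc1OCC(C)OC(=O)[C@@H](N)C(C)C`, gives 3.9% in this assay. Compound 2, `COc1cc(-n2cnc3cc(-c4ccc(Cl)cc4)sc3c2=O)ccc1OCC(C)(C)OC(=O)CN`, gives 6.9% in this assay, and compound 3, `COc1cc(-n2cnn3cc(-c4ccc(Cl)cn4)cc3c2=O)ccc1OCC1(OC(=O)CN)CC(F)(F)C1`, gives 4.4% in this assay. On the numbers shown, compound 1 has the lowest number of the three, but its gaps to compound 3 and to compound 2 both lie within the usual scatter of this assay, so the three compounds cannot be told apart on these data.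

Compound 4, `COc1cc(-n2cnn3cc(-c4ccc(Cl)cc4)cc3c2=O)ccc1OCC(OC(=O)[C@@H](N)C(C)C)C1CC1`, has not yet been measured. It differs from compound 1 in one place: cyclopropyl in place of methyl on a saturated chain carbon bound to an oxygen next to a carbonyl group and a saturated chain carbon. Among the measured compounds shown here, no step between two measured compounds shows what such a change does here, so the expectation rests on the three measured numbers alone, which all sit close together at a low level of inhibition. The step from compound 1 to compound 4 is therefore expected to be small, in no set direction, and not beyond the scatter: a number 1.1 percentage points higher from compound 1 to compound 4 (within the scatter). For compound 4 the estimate in this assay is 5%, with a range from 0% to 15%.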

Compound 4, a percentage reported as inhibition, in the whole organism at one dose (the size of the read-out at that dose, not a potency): 0%
Compound 4: middle estimate off by 5 percentage points, on the high side, within the range that was stated.
By their numbers in this assay, from the lowest: compounds 4, 1, 3 and 2 (each within the scatter of the next).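

Among the compounds shown here, this pair is the first in this assay that differs in only one place, so it gives a first direct reading of this position: cyclopropyl in place of methyl on a saturated chain carbon bound to an oxygen next to a carbonyl group and a saturated chain carbon gives a number 3.9 percentage points lower from compound 1 to compound 4 (within the scatter). At this place, then, adding the three-membered ring brings no difference that can be told from the scatter, and inhibition stays low. No measurement shown here offers an explanation for this result.

Both compounds sit so low on the scale that this pair says little about how much the position can matter. Going by these compounds, whether an ethyl group, a longer chain or a phenyl ring on this carbon would give a step beyond the scatter remains open.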